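The compounds below may be only part of what the source reports. "The series", "measured", "known", "first", "only" and "open" are said of these compounds alone.

Of the compounds shown here, three of one shared core have been measured in a physicochemical assay for solubility, read by HPLC, in phosphate buffer, with a stated time of 24 h, at pH 6.8; a higher number here means a more soluble compound, a lower number a less soluble compound. Compound 1 `CC1(OC(=O)N2CCC3(CC2)CC(CCCOc2ccc(S(C)(=O)=O)c(F)c2)C3)CC1` reaches only a limit of the assay, < 0.15 ug/mL. Compound 2 `CC(C)c1noc(N2CCC3(CC2)CC(CCCOc2ccc(S(C)(=O)=O)cc2)C3)n1` likewise returns only a limit, < 0.13 ug/mL. Among the compounds with values here, compound 3 `CC(C)OC(=O)N1CCC2(CC1)CC(CCCOc1ccc(C(=O)NC3CC3)c(F)c1)C2` is the sole member to give a number, and in this assay compound 3 gives 0.21 ug/mL. The other two values sit at the limit of < 0.13 ug/mL in this assay, at which 1 of the 3 values shown sits, and (the limit of < 0.15 ug/mL in this assay, at which 1 of the 3 values shown sits). Compound 4 `CC(C)OC(=O)N1CCC2(CC1)CC(CCCOc1ccc(C(=O)N3CC(O)C3)c(F)c1)C2` differs from compound 3 in one place: 3-hydroxyazetidin-1-yl in place of cyclopropylamino on a carbonyl carbon. Within the data shown here, no step between measured compounds is available to size this change. In this assay compound 4 is expected to show a modest rise, the step from compound 3 to compound 4 being estimated at a 7.1-fold higher number from compound 3 to compound 4 (0.85 log units; beyond the scatter). Compound 4 is thus estimated at 1.5 ug/mL, within a range of 0.4 ug/mL to 6 ug/mL.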

Compound 4, solubility: 1.89 ug/mL
Beside the measured number, compound 4's estimate is 1.3-fold (0.10 log units) below it, within the range that was stated.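

In this assay, within the data shown here, the carbonyl carbon whose other neighbour is an aromatic carbon proves to be a place where one change moves the read-out: 3-hydroxyazetidin-1-yl in place of cyclopropylamino gives a 9.0-fold higher number from compound 3 to compound 4 (0.95 log units; beyond the scatter) and so provides the first step in this set that can be sized. Among these compounds, nothing measured so far explains the rise.

As far as these compounds go, whether the step depends on the hydroxyl or on the four-membered ring stays open. Plain azetidin-1-yl, or the same ring carrying an amine or a carboxylic acid in place of the hydroxyl, would help to separate the two.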